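Hydrogen in place of methoxy: notes on two series

The source may hold more compounds than are shown below. What is called first, only, known or untested is meant among the compounds shown, and "the series" means these compounds.

Measured compounds:
compound 1, `COc1cc(-c2cc(/C=C/C(=O)c3ccc(N)cc3)[nH]n2)cc(OC)c1OC`, gives -93% in a functional assay on SF-539 cells (Homo sapiens) for cytotoxicity, read by sulforhodamine B assay, with a stated time of 48 h, tested at 10 uM; a higher number here means a weaker effect of the compound at the concentration tested, a lower number a stronger effect;
compound 2, `COc1ccc(-c2cc(/C=C/C(=O)c3ccc(N)cc3)[nH]n2)cc1OC`, gives -73% in this assay;
compound 3, `COc1cc(C(=O)/C=C/c2cc(-c3cc(OC)c(OC)c(OC)c3)n[nH]2)cc(OC)c1OC`, gives -80% in this assay.

Compound 1 and compound 2 share one core and differ in one place: hydrogen in place of methoxy on an aromatic carbon. This change gave a number 20 percentage points higher from compound 1 to compound 2 (beyond the scatter), a step that lies beyond the scatter.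

Compound 3 carries a different core. How the core of compound 3 differs from the core of compound 1 is not broken down here; compound 3 and compound 2 lie within the scatter of each other, while compound 3 and compound 1 lie beyond it.

Compound 4, `COc1ccc(-c2cc(/C=C/C(=O)c3cc(OC)c(OC)c(OC)c3)[nH]n2)cc1OC`, is not yet measured. It differs from compound 3 by hydrogen in place of methoxy on an aromatic carbon. The surroundings of the place are the same as in the change from compound 1 to compound 2, so this is the same change, now made on the core of compound 3. Among the compounds with values here, only one earlier example of this change is known, so the expectation rests on that single step. The expected step is a number 20 percentage points higher from compound 3 to compound 4 (beyond the scatter), because a number 20 percentage points higher from compound 1 to compound 2 (beyond the scatter) is the only measured record of the change in this assay and the new step is taken to be of about the same size. Whether the second core moves the same way is not known from the measured compounds, so the range is kept wide. For compound 4 the expected value in this assay is -60%, estimated to fall between -78% and -38%.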

Compound 4, a percentage reported as activity, at one concentration (the size of the read-out at that concentration, not a potency): -85%
Compound 4: the middle estimate sits 25 percentage points above what was measured, outside the stated range (below it).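

Carried to the core of compound 3, hydrogen in place of methoxy does not repeat its earlier behaviour in this assay: the change gives a number 5 percentage points lower from compound 3 to compound 4 (within the scatter). Set side by side, the two records of this one change disagree: the same change on two cores in this assay, a number 20 percentage points higher (beyond the scatter) from compound 1 to compound 2 and a number 5 percentage points lower (within the scatter) from compound 3 to compound 4, 25 percentage points apart, beyond the scatter of two such steps This shows that, within this series, the step measured on the core of compound 1 cannot simply be transferred to the core of compound 3, although it does not show which difference between the two cores separates the outcomes, and two pairs give no rule for any further core.

The compounds shown leave open how the same change would behave on a third core, for instance one carrying a carboxylic acid where compound 1 and compound 2 carry their amine, and whether such a core would follow the step seen on the core of compound 1, the step seen on the core of compound 3, or neither. They also leave open what other replacements for the methoxy group at this place would do on either core, such as a hydroxy group or a chlorine atom, since hydrogen is the only replacement shown here.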